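A smaller amine on the sulfonyl side chain

The compounds below may be only part of what the source reports. "The series", "measured", "known", "first", "only" and "open" are said of these compounds alone.

Compound 1 `CN1CCCN(CCCS(=O)(=O)c2ccc3nc(NC(=O)NC(=O)c4ccccc4Cl)sc3c2)CC1` is the weaker of the two measured compounds; in an assay on HEK293 cells for displacement of a labelled ligand from growth hormone secretagogue receptor type 1 (Homo sapiens), with a stated time of 60 min (on this read-out lower numbers stand for stronger inhibition and higher numbers for weaker inhibition), compound 1 gives 4.2 nM. Its only measured companion, compound 2 `CN1CCN(CCCS(=O)(=O)c2ccc3nc(NC(=O)NC(=O)c4cc(-n5cccn5)c(Cl)cc4Cl)sc3c2)CC1`, differs from it in several places at once and gives 0.31 nM in this assay, a lower number that lies beyond the scatter, so compound 1 holds the highest value of the pair. Compound 3 `CN(C)CCCS(=O)(=O)c1ccc2nc(NC(=O)NC(=O)c3ccccc3Cl)sc2c1` has not been measured; it arises from compound 1 by a single change, (dimethylamino in place of 4-methyl-1,4-diazepan-1-yl on a saturated chain carbon, three bonds along the chain from a sulfonyl sulfur), so that the nitrogen at the end of the three-carbon chain now carries two methyl groups instead of forming part of a seven-membered ring with a second nitrogen. Among the measured compounds shown here, no measured pair shows this change on its own, and compound 2 carries other differences, so no direct guide is available. The account expects a modest weakening, a step of a 1.9-fold higher number from compound 1 to compound 3 (0.28 log units; within the scatter) in this assay, which may still sit within the scatter. For compound 3 the expected value in this assay is 8 nM, with a range from 2 nM to 30 nM.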

Compound 3, half-maximal inhibitory concentration: 8.7 nM
Estimate against measurement, compound 3: 1.1-fold (0.04 log units) below; the measured number falls inside the stated range.
By their numbers in this assay, from the lowest: compound 2; then compound 1; then compound 3.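

Exchanging 4-methyl-1,4-diazepan-1-yl for dimethylamino on a saturated chain carbon, three bonds along the chain from a sulfonyl sulfur, provides the only single-place comparison among these compounds, and in this assay it gives a 2.1-fold higher number from compound 1 to compound 3 (0.32 log units; beyond the scatter) on a modest scale. At this position, therefore, the seven-membered ring and its second nitrogen can be removed, reducing the group from 8 heavy atoms to 3, with only this modest loss in the measured inhibition, and the ring is not required for compound 3 to retain a measurable effect in this assay. No available measurement bears on what lies behind the size of this step.

The compounds shown leave open how other groups at the end of the 3-carbon chain, such as a morpholine, a piperidine or a primary amine, or a longer chain carrying the same dimethylamino group, would compare with compound 1 and compound 3. They also leave open whether the same exchange would produce a step of similar size on the more heavily substituted aromatic ring carried by compound 2.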